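Benzamide variation on the shared core: the chloro step

A few compounds are considered here, and "the series" means these few. Any claim that something is new, unique, unknown or untested is made for them only; others in the source may bear on it.

compound 1 `O=C(NCc1ccc(CNS(=O)(=O)c2ccccc2)cc1)c1cccnc1` — 10 nM
compound 2 `O=C(NCc1ccc(CNS(=O)(=O)c2ccccc2)cc1)c1ccccc1F` — 1000 nM
compound 3 `O=C(NCc1ccc(CNS(=O)(=O)c2ccccc2)cc1)c1ccccc1` — 1 nM

In an assay on MDA-MB-231 cells for binding affinity to C-X-C chemokine receptor type 4 (Homo sapiens), read by immunofluorescence and microscopy, with stated times of 10 min and 30 min (a lower number here means that less compound is needed, a higher number that more compound is needed for the effect), compound 3 gives 1 nM, the lowest number of the three: the step of a 10-fold lower number from compound 1 to compound 3 (1.00 log units; beyond the scatter) and the step of a 1000-fold lower number from compound 2 to compound 3 (3.00 log units; beyond the scatter) both lie beyond the scatter. Compound 4 `O=C(NCc1ccc(CNS(=O)(=O)c2ccccc2)cc1)c1ccc(Cl)cc1` has not yet been measured in this assay. The change from compound 3 to compound 4 is chloro in place of hydrogen on an aromatic carbon, on an aromatic carbon of a six-membered aromatic ring of carbon only, para to a large group. Going by the values given here, no measured step sets chloro against hydrogen. The nearest bearing is a 1000-fold lower number from compound 2 to compound 3 (3.00 log units; beyond the scatter), a large step on the same six-membered aromatic ring of carbon only, but that step concerned fluoro, not chloro, and not this aromatic carbon, so it is a loose guide. The ring change a 10-fold lower number from compound 1 to compound 3 (1.00 log units; beyond the scatter) says nothing about a substituent. A step of uncertain size toward a higher number is therefore expected for a 10-fold higher number from compound 3 to compound 4 (1.00 log units; beyond the scatter). Compound 4 is expected to give 10 nM, within 1 nM to 100 nM.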

Compound 4, effective concentration (reported as EC, without a stated level of effect): 100 nM
Beside the measured number, compound 4's estimate is 10-fold (1.00 log units) below it, and the stated range covers the measured number.
By their numbers in this assay, from the lowest: compound 3; then compound 1; then compound 4; then compound 2.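

In this assay, going by these compounds alone, the first measured step for a substituent at this place, on an aromatic carbon para to a large group, is a 100-fold higher number from compound 3 to compound 4 (2.00 log units; beyond the scatter), so adding one chlorine atom to the phenyl group costs much of the number held by compound 3. The step of a 10-fold lower number from compound 2 to compound 4 (1.00 log units; beyond the scatter) leaves compound 4 ahead of the 2-fluorophenyl amide, but halogen and place change together there, so it separates neither effect. The step of a 10-fold higher number from compound 1 to compound 4 (1.00 log units; beyond the scatter) puts 4-chlorophenyl behind pyridin-3-yl on the carbonyl carbon, whereas unsubstituted phenyl stands ahead of it.

As far as these compounds go, whether a methoxy group, an amine or a carboxylic acid at this place would give a similar step remains open, as does the effect of chloro on another aromatic carbon of the ring. Nothing available explains the step from hydrogen to chloro.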